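Trifluoromethyl in Place of Methoxycarbonyl, Read on Lung Cells

A few compounds are considered here, and "the series" means these few. Any claim that something is new, unique, unknown or untested is made for them only; others in the source may bear on it.

Compound 1, `COC(=O)c1ccc(-c2cn(CCCC(=O)Nc3ccc(C)cc3)nn2)cc1`: > 100000 nM
Compound 2, `Cc1ccc(NC(=O)CCCn2cc(-c3ccc(C(F)(F)F)cc3)nn2)cc1`: 25000 nM
Compound 3, `COC(=O)c1ccc(-c2cn(CCCC(=S)Nc3ccc(-c4ccccc4)cc3)nn2)cc1`: 42300 nM

Of the compounds shown here, three have been tested in a functional assay on A549 cells (Homo sapiens) for inhibition, read by MTT assay, with a stated time of 72 h; on this read-out lower numbers stand for stronger inhibition and higher numbers for weaker inhibition. Compound 1 reaches no number there, only a limit, > 100000 nM; this is the limit of > 100000 nM in this assay, at which 1 of the 3 values shown sits. In this assay compound 2 gives 25000 nM, and compound 3 gives 42300 nM; the two sit within the scatter of each other, so no order between them can be read.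

Compound 2 differs from compound 1 by trifluoromethyl in place of methoxycarbonyl on an aromatic carbon, and that change brought an at least 4.0-fold lower number from compound 1 to compound 2 (0.60 log units; beyond the scatter). Compound 4, `FC(F)(F)c1ccc(-c2cn(CCCC(=S)Nc3ccc(-c4ccccc4)cc3)nn2)cc1`, has not yet been measured. It differs from compound 3 by trifluoromethyl in place of methoxycarbonyl on an aromatic carbon, the same change seen from compound 1 to compound 2, made on a different core; how the core of compound 3 differs from that of compound 1 is not broken down here.

Taking the earlier step as a guide, compound 4 is expected near 12000 nM in this assay, between 4000 nM and 40000 nM, and the expected step is a 3.5-fold lower number from compound 3 to compound 4 (0.55 log units; beyond the scatter). This rests on compound 2 at 25000 nM and on the step of an at least 4.0-fold lower number from compound 1 to compound 2 (0.60 log units; beyond the scatter), with the lower confidence that a single precedent allows.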

Compound 4, half-maximal inhibitory concentration: 1000 nM
Estimate against measurement, compound 4: 12-fold (1.08 log units) above; the whole stated range lies above it.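

In this assay, trifluoromethyl in place of methoxycarbonyl lowered the number on the core of compound 3 as well, with a 42-fold lower number from compound 3 to compound 4 (1.63 log units; beyond the scatter), so the direction of the change carried over from one core to the other. Set side by side, the two steps do not settle whether its size carried over too: the same change on two cores in this assay, an at least 4.0-fold lower number (0.60 log units; beyond the scatter) from compound 1 to compound 2 and a 42-fold lower number (1.63 log units; beyond the scatter) from compound 3 to compound 4; the limit leaves it open whether they differ. Compound 1 stands only at a limit, and a single pair on each of two cores does not show that the change would read the same way on any further core: the limit of > 100000 nM in this assay, at which 1 of the 4 values shown sits.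

The compounds shown leave open which part of the core of compound 3, as against the core of compound 1, goes with the larger step seen there. They also leave open how a nitrile, a chlorine or a carboxylic acid would read in place of trifluoromethyl on either core, and whether a longer chain would keep the step.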